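The compounds below may be only part of what the source reports. "The series", "measured", "known", "first", "only" and "open" are said of these compounds alone.

Measured so far:
- compound 1 `COc1cccc(Cn2cc(-c3ccc(OC)c(OC)c3OC)nn2)c1`. In a functional assay on B16 cells (Mus musculus) for cytotoxicity, read by MTT assay, with a stated time of 48 h (on this read-out higher numbers stand for weaker inhibition and lower numbers for stronger inhibition), compound 1 gives > 100000 nM, which is a limit of the assay.
- compound 2 `COc1cccc(Cn2cc(-c3ccc4ccccc4c3)nn2)c1`. In this assay compound 2 gives > 100000 nM, again a limit of the assay and not a number.

Compound 2 therefore stands at the limit of > 100000 nM in this assay, at which 2 of the 2 values shown sit; nothing shown places it anywhere within the measurable range, and the same holds for compound 1, so no step between measured compounds exists to calibrate against.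

Compound 3 `OCCCn1cc(-c2ccc3ccccc3c2)nn1` is the next compound and is yet to be measured in this assay. Against compound 2 the change is 2-hydroxyethyl in place of 3-methoxyphenyl on a saturated chain carbon bound to an aromatic nitrogen. The shared core of compound 2 and compound 3 is otherwise untouched.

With both values shown sitting at the limit, no ground exists for expecting a step beyond the scatter in either direction. The step that the limit leaves unreadable from compound 2 to compound 3 is expected to be none beyond the usual scatter. Compound 3 is expected to read 150000 nM, within 50000 nM to 500000 nM, most probably reported again as a limit.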

Compound 3, half-maximal inhibitory concentration: > 100000 nM
Compound 3 ended at the assay's limit; the forecaster's own chance of this, stated with the estimate: 85%; the middle value lies beyond the limit too.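

Compound 2 and compound 3 both sit at a limit in this assay, so no step between them can be read: the limit of > 100000 nM in this assay, at which 3 of the 3 values shown sit.

The compounds shown leave open whether any change to the shared core brings a value within the measurable range of this assay.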